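Working notes: from compound 1 to compound 3

The source may report more compounds than this note shows. Statements on the series, on what has been measured and on what is new or still open speak of the compounds shown alone.

In a functional assay on HT-29 cells (Homo sapiens) for inhibition, read by sulforhodamine B assay, with a stated time of 72 h (on this read-out higher numbers stand for weaker inhibition and lower numbers for stronger inhibition), compound 1 `COc1cc2c(Nc3ccc(F)c(Cl)c3)ncnc2cc1OCCOCCn1ccnc1[N+](=O)[O-]` gives 9860 nM. Compound 2 `C#Cc1cccc(Nc2ncnc3cc(OCCOCCn4ccnc4[N+](=O)[O-])c(OC)cc23)c1` gives 8770 nM, so the two lie within the scatter of each other, and compound 1 has no neighbour beyond the scatter so far.

Compound 3 `COc1cc2c(Nc3ccc(OCc4cccc(F)c4)c(Cl)c3)ncnc2cc1OCCOCCn1ccnc1[N+](=O)[O-]` awaits measurement. Its change from compound 1 is (3-fluorobenzyl)oxy in place of fluoro on an aromatic carbon, ortho to a chloro group and para to a large group.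

Within the data shown here, only one measured step bears on this: a 1.1-fold lower number from compound 1 to compound 2 (0.05 log units; within the scatter). That step replaces the whole group on the nitrogen, and it shows that one such replacement left the number within the scatter. Among the measured compounds shown here, it does not cover the entering aromatic ring, and no measured compound carries (3-fluorobenzyl)oxy. The data therefore give no firm direction, and a modest move towards a lower number is only a tentative expectation. The estimated change is a 1.6-fold lower number from compound 1 to compound 3 (0.22 log units; within the scatter), and a result within the scatter would fit equally well. For compound 3 the expected value is 6000 nM, with an estimated range of 2000 nM to 14000 nM.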

Compound 3, half-maximal inhibitory concentration: 7640 nM
For compound 3 the middle estimate is 1.3-fold (0.10 log units) below the measured one; the measured number falls inside the stated range.
By their numbers in this assay, from the lowest: compounds 3, 2 and 1 (each within the scatter of the next).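

In this assay the step at this position reads a 1.3-fold lower number from compound 1 to compound 3 (0.11 log units; within the scatter), so the number does not separate (3-fluorobenzyl)oxy from the fluoro it replaces, even though 9 heavy atoms and one six-membered aromatic ring of carbon only enter where 1 heavy atom leaves. The earlier step concerned the group on the nitrogen; this one adds that a much larger group on an aromatic carbon, ortho to a chloro group and para to a large group, also leaves the number within the scatter. No measurement at hand bears on why this change leaves the number within the scatter.

Still open, on these data alone, is whether a group of another kind at this position, such as an amine or a carboxylic acid, would move the number beyond the scatter. Also open, as far as these compounds go, is whether the fluorine on the entering ring matters, as a plain benzyloxy group would show, and whether any change on this aromatic carbon can move the number beyond the scatter.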